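Following Compound 2 to Compound 3 at the Assay Limit

The source may report more compounds than this note shows. Statements on the series, on what has been measured and on what is new or still open speak of the compounds shown alone.

Of the compounds shown here, two have been measured so far. Compound 1 `Brc1cccc(Nc2nc(/C=C/c3ccccc3)nc3ccsc23)c1` was tested in a functional assay on L02 cells (Homo sapiens) for inhibition, read by Griess assay, with stated times of 1 h and 24 h; on this read-out lower numbers stand for stronger inhibition and higher numbers for weaker inhibition; in that assay compound 1 gives > 1000000 nM, which is a limit of the assay and not a number. Compound 2 `CCN1CCN(c2nc(/C=C/c3cc(OC)c(OC)c(OC)c3)nc3ccsc23)CC1` was run in this assay as well; there compound 2 gives > 1000000 nM, again a limit rather than a measured number. Within the data shown here, compound 2 therefore stands exactly where the only other value shown stands: the limit of > 1000000 nM in this assay, at which 2 of the 2 values shown sit. Nothing separates the two on the numbers available.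

Compound 3 `COc1cc(/C=C/c2nc(NCc3ccco3)c3sccc3n2)cc(OC)c1OC` has not yet been measured in this assay. It differs from compound 2 in one place: ((furan-2-yl)methyl)amino in place of 4-ethylpiperazin-1-yl on an aromatic carbon.

No step between measured compounds is shown, so the effect of this change cannot be read from the data. He expects the step of a number no higher from compound 2 to compound 3 (the limit leaves the size open) to be none beyond the scatter, in either direction. Compound 3 is accordingly estimated at 1000000 nM, with a range from 200000 nM to 5000000 nM, and most likely this assay will again report only a limit for compound 3.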

Compound 3, half-maximal inhibitory concentration: 189000 nM
Estimate against measurement, compound 3: 5.3-fold (0.72 log units) above; measured number below the stated range.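

In this assay, setting ((furan-2-yl)methyl)amino in place of 4-ethylpiperazin-1-yl on an aromatic carbon, next to the ring nitrogen of the shared core, brings an at least 5.2-fold lower number from compound 2 to compound 3 (0.72 log units; beyond the scatter). Among these compounds, this shows that the group at this position can move the read-out, which the earlier compounds could not show, and compound 3, at 189000 nM, is the first of the three to give a number rather than a limit. The step has only a lower bound on its size, since its starting point is a limit and not a number: the limit of > 1000000 nM in this assay, at which 2 of the 3 values shown sit.

The compounds shown leave open which part of the change carries the step, as the swap replaces a six-membered non-aromatic ring with 2 hetero atoms by a five-membered aromatic ring while also bringing in a hydrogen-bond donor. From the compounds shown here alone, a benzylamino group, with a benzene ring in place of the furan, a morpholine ring or a simple ethylamino chain at the same carbon could separate these features, and how far the number can fall at this position also remains unknown.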